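Cytotoxicity notes: from compound 1 to compound 3

The source may report more compounds than this note shows. Statements on the series, on what has been measured and on what is new or still open speak of the compounds shown alone.

Measured so far:
- compound 1 `CCCCNC(=O)Nc1cc2nc(C3CCCCC3)[nH]c2cc1N(CC)CC`; in an ADME assay on Vero cells (Chlorocebus sabaeus) for cytotoxicity, read by resazurin assay, with a stated time of 3 days (a lower number here means a stronger inhibitor, a higher number a weaker inhibitor), compound 1 gives > 100 ug/mL, a limit of the assay
- compound 2 `CCCCNC(=O)Nc1cc2nc(C3CCCCC3)[nH]c2cc1N1CCCC1`; in this assay compound 2 gives > 100 ug/mL, again a limit

Compound 1 stands only at a limit in this assay, with no number of its own: the limit of > 100 ug/mL in this assay, at which 2 of the 2 values shown sit. For the measured compounds named here, the one measured step, a step that the two limits leave unreadable from compound 1 to compound 2, is a change of pyrrolidin-1-yl in place of diethylamino on an aromatic carbon and stays unreadable between two limits.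

Compound 3 `CCN(CC)c1cc2[nH]c(C3CCCCC3)nc2cc1NC(=O)c1ccc(F)cc1F` differs from compound 1 by 2,4-difluorophenyl in place of butylamino on a carbonyl carbon. Going by the values given here, no measured step touches this carbonyl carbon, and the single measured step gives no size, so no direction can be read for this assay. The step of a number no higher from compound 1 to compound 3 (the limit leaves the size open) is therefore only an estimate. Compound 3 is expected to sit near 100 ug/mL, between 30 ug/mL and 300 ug/mL, most likely again only as a limit.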

Compound 3, half-maximal inhibitory concentration: > 100 ug/mL
Compound 3 was reported as a limit; the forecaster's own chance of this, stated with the estimate: 65%; the middle value sits exactly at the limit.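

No new step can be read: compound 1 and compound 3 both stand only at a limit in this assay, and the change between them has no readable size. The compounds shown leave open at what concentration any of them reaches half-maximal inhibition, and whether either change shifts it.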